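The source may report more compounds than this note shows. Statements on the series, on what has been measured and on what is new or still open speak of the compounds shown alone.

Measured so far:
compound 1, `CC(C)NCc1nnc(-c2ccccc2-c2ccccc2)s1`: 35 mg/kg
compound 2, `CN(C)Cc1nnc(-c2ccccc2-c2ccccc2)s1`: 35 mg/kg

In a functional assay on the whole organism with Mus musculus as the target (a lower number here means that less compound is needed, a higher number that more compound is needed for the effect), compound 2 gives 35 mg/kg. It stands level with compound 1, since no change at the digits printed from compound 1 to compound 2 (within the scatter). Compound 3, `NCCCc1nnc(-c2ccccc2-c2ccccc2)s1`, carries 2-aminoethyl in place of dimethylamino on a saturated chain carbon bound to an aromatic carbon. Going by the values given here, only the step from compound 1 to compound 2 bears on this move, and that step was within the scatter, but it exchanged one amine for another of the same kind, whereas here dimethylamino gives way to 2-aminoethyl, so it is only a loose guide. Compound 3 is therefore expected close to compound 2, with a 1.1-fold higher number from compound 2 to compound 3 (0.06 log units; within the scatter) as the estimated step, and an expected value of 40 mg/kg, between 15 mg/kg and 110 mg/kg.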

Compound 3, dose for half-maximal effect: > 200 mg/kg
Compound 3 was reported as a limit (the forecaster's own chance of this, stated with the estimate: 10%); at least 5.0-fold (0.69 log units) between middle value and limit.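

In this assay, dimethylamino in place of isopropylamino on a saturated chain carbon bound to an aromatic carbon had shown no change at the digits printed from compound 1 to compound 2 (within the scatter), so amine exchange there seemed to matter little. That no longer holds for 2-aminoethyl in place of dimethylamino, which gives an at least 5.7-fold higher number from compound 2 to compound 3 (0.75 log units; beyond the scatter), while 2-aminoethyl in place of isopropylamino gives an at least 5.7-fold higher number from compound 1 to compound 3 (0.75 log units; beyond the scatter). Compound 3 is reported only as a limit, not a number: the limit of > 200 mg/kg in this assay, at which 1 of the 3 values shown sits.

The compounds shown do not separate the longer 3-aminopropyl chain from the change to an unsubstituted amine. A plain aminomethyl group or a 3-(dimethylamino)propyl chain would tell these two apart.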